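Acetylating the hydroxy group of compound 3

This account rests on a few compounds, and the source may have more. Where it says the series, first, only, none or still open, it means among the compounds named here.

Compound 1 `C=C(C)CC[C@]1(C)C2=CCC[C@](C)(C[C@H](O)c3ccoc3)[C@H]2CC[C@H]1C`: 30000 nM
Compound 2 `C=C(C)CCC[C@]1(C)C2=CCC[C@](C)(C[C@@H](OC(C)=O)C3=CC(=O)OC3O)[C@H]2CC[C@H]1C`: 2900 nM
Compound 3 `C=C(C)CC[C@]1(C)C2=CCC[C@](C)(C[C@@H](O)C3=CC(=O)OC3O)[C@H]2CC[C@H]1C`: 3600 nM

These values come from a functional assay on HT-29 cells (Homo sapiens) for antiproliferative activity, read by XTT assay, with a stated time of 72 h; a higher number here means a weaker inhibitor, a lower number a stronger inhibitor. Compound 3, at 3600 nM, stands in the middle of the three numbers, though its value and that of compound 2 lie within the scatter of each other. Compound 1 gives the clearly higher number, and an 8.3-fold lower number from compound 1 to compound 3 (0.92 log units; beyond the scatter) is a modest step beyond the scatter.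

The next compound is compound 4 `C=C(C)CC[C@]1(C)C2=CCC[C@](C)(C[C@@H](OC(C)=O)C3=CC(=O)OC3O)[C@H]2CC[C@H]1C`, which differs from compound 3 at one place: acetyl in place of hydrogen on an oxygen on a saturated carbon. In words, acetyl replaces hydrogen on an oxygen on a saturated carbon, turning hydroxy into acetoxy.

Among the measured compounds shown here, no measured step isolates this change. For the measured compounds named here, the single measured step concerns a different group, so it shows that this series can respond in this assay but says nothing direct about acetylation. The nearest evidence is compound 2, which also carries acetoxy and gives 2900 nM, within the scatter of compound 3.

No change beyond the scatter is therefore expected, and the estimated step is a 1.1-fold lower number from compound 3 to compound 4 (0.05 log units; within the scatter). For compound 4 the expected value is 3200 nM, with an estimated range from 1400 nM to 7500 nM.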

Compound 4, half-maximal inhibitory concentration: 4800 nM
The estimate for compound 4 lay 1.5-fold (0.18 log units) below the measured number, and the stated range covers the measured number.
By their numbers in this assay, from the lowest: compounds 2, 3 and 4 (each within the scatter of the next); then compound 1.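

In this assay, putting acetyl in place of hydrogen on an oxygen on a saturated carbon, which turns hydroxy into acetoxy, gives a 1.3-fold higher number from compound 3 to compound 4 (0.12 log units; within the scatter), so in this pair the free hydroxy and its acetate cannot be told apart. The side chain adds a second reading: with acetoxy held constant, 1-methylethenyl in place of 2-methylprop-2-en-1-yl on a saturated chain carbon, two bonds along the chain from a saturated ring carbon, gives a 1.7-fold higher number from compound 2 to compound 4 (0.22 log units; within the scatter). Both steps are small beside an 8.3-fold lower number from compound 1 to compound 3 (0.92 log units; beyond the scatter), which remains the only step shown here that lies beyond the scatter, so among these compounds only the change of the group on the saturated chain carbon bound to a saturated ring carbon separates the values. No other data bear on this result.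

The compounds shown leave open whether a benzoyl group or a methyl group on this oxygen, or an amine in place of the hydroxy, would also stay within the scatter of compound 3. They also leave open whether these two steps would read the same on any other cell line.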